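Swapping tert-butyl for 3-fluorocyclobutyl on a shared core

The compounds below may be only part of what the source reports. "The series", "measured", "known", "first", "only" and "open" are said of these compounds alone.

Measured compounds:
compound 1, `CC(C)(C)n1nc(Oc2cc(O)ccn2)c2c(N)ncnc21`, gives 1.4 h
compound 2, `Nc1ncnc2c1c(Oc1cccc(C(F)(F)F)c1)nn2[C@H]1C[C@H](O)C1`, gives 1.25 h
compound 3, `Nc1ncnc2c1c(Oc1cc(C(F)(F)F)ccn1)nn2[C@H]1CC[C@@H](CO)CC1`, gives 1.6 h

Of the compounds shown here, three on a shared core have been measured in an ADME assay on microsomes from liver (Homo sapiens) for metabolic stability, read by LC-MS, using NADPH, with a stated time of 10 min, tested at 10 uM; a higher number here means that the compound lasts longer, a lower number that the compound disappears faster. Compound 1 stands in the middle of the three readings, yet its half-life is within the scatter of both compound 2 and compound 3, so none of the three can be set apart from the others on these numbers alone. Among the measured compounds shown here, no pair among them differs in only one place, so no single step between measured compounds is available to guide the next one.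

Compound 4, `Nc1ncnc2c1c(Oc1cc(O)ccn1)nn2[C@H]1C[C@H](F)C1`, has not yet been measured in this assay. It departs from compound 1 in one place: 3-fluorocyclobutyl in place of tert-butyl on an aromatic nitrogen. The tert-butyl has no ring; the 3-fluorocyclobutyl brings a four-membered non-aromatic ring of carbon only and two defined stereocentres, while donors, acceptors and charge stay unchanged.

For the measured compounds named here, with no step to lean on, the account expects no change beyond the scatter in this assay for this exchange, in either direction. Compound 4 is estimated at 1.3 h, between 0.7 h and 2.6 h, which means an expected step of a 1.1-fold lower number from compound 1 to compound 4 (0.03 log units; within the scatter).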

Compound 4, half-life: 1.03 h
The estimate for compound 4 lay 1.3-fold (0.10 log units) above the measured number, and the stated range covers the measured number.
By their numbers in this assay, from the lowest: compounds 4, 2, 1 and 3 (each within the scatter of the next).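

Among the compounds shown here, the exchange of tert-butyl for 3-fluorocyclobutyl on an aromatic nitrogen gives the first step on the shared core between compounds that differ in one place, and in this assay it reads a 1.4-fold lower number from compound 1 to compound 4 (0.13 log units; within the scatter), so this one pair shows no change in half-life that can be told apart from the scatter. For the compounds shown here, at this position, then, a four-membered non-aromatic ring of carbon bearing a fluorine, with two defined stereocentres, stands in for an open tert-butyl with no measurable consequence in this reading, something the earlier compounds could not show, as no two of them differed in only one place. Nothing available here bears on why the reading behaves this way.

The compounds shown leave open whether the fluorine and the four-membered ring each matter on their own, as a plain cyclobutyl with no fluorine or the other stereoisomer of the 3-fluorocyclobutyl would be needed to separate them. They also leave open how far this tolerance extends at the same nitrogen, for instance to an amine-bearing ring, a carboxylic acid or a longer chain such as n-butyl.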